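A Fluoro-to-Isopropoxy Swap in a Cytotoxicity Series

The source may report more compounds than this note shows. Statements on the series, on what has been measured and on what is new or still open speak of the compounds shown alone.

Among the measured compounds shown here, in an ADME assay on MIA PaCa-2 cells (Homo sapiens) for cytotoxicity, read by MTT assay, with a stated time of 72 h (a higher number here means a weaker inhibitor, a lower number a stronger inhibitor), compound 2 `COc1ccc(C2=C(c3cc(OC)c(OC)c(OC)c3)C(=O)C(O)C2)cc1F` gives 64 ug/mL as the only actual number so far. Compound 1 `COc1ccc(C2=C(c3cc(OC)c(OC)c(OC)c3)C(=O)C(O)C2)cc1NC(=O)c1ccccc1` reads > 100 ug/mL and this is a limit of the assay, not a number. Compound 3 `COc1ccc(C2=C(c3cc(OC)c(OC)c(OC)c3)C(=O)C(O)C2)cc1OC(C)C` is still unmeasured. It differs from compound 2 in one place, with isopropoxy in place of fluoro on an aromatic carbon, ortho to a methoxy group, and the count for that swap runs isopropoxy in place of fluoro on an aromatic carbon in full. For the measured compounds named here, the one measured step at this aromatic carbon is an at least 1.5-fold lower number from compound 1 to compound 2 (0.19 log units; that floor lies within the scatter) and it puts fluoro in place of benzamido. From the compounds shown here alone, its true size stays open because one end of it is the limit of > 100 ug/mL in this assay, at which 1 of the 2 values shown sits, and so it offers only a floor. With only an at least 1.5-fold lower number from compound 1 to compound 2 (0.19 log units; that floor lies within the scatter) to lean on, no step beyond the scatter is expected in this assay for the new swap. The estimate is a 1.1-fold higher number from compound 2 to compound 3 (0.04 log units; within the scatter) as the expected step. Compound 3 is estimated at 70 ug/mL with 30 ug/mL to 150 ug/mL as its expected range.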

Compound 3, half-maximal inhibitory concentration: > 100 ug/mL
Compound 3: no number, only a limit; the forecaster's own chance of this, stated with the estimate: 35%; at least 1.4-fold (0.15 log units) between middle value and limit.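

In this assay compound 3 gives > 100 ug/mL, which is a limit of the assay and not a number. Putting isopropoxy in place of fluoro on this aromatic carbon gives an at least 1.5-fold higher number from compound 2 to compound 3 (0.19 log units; that floor lies within the scatter), so the data show only a minimum size for this change, and that minimum cannot be told apart from ordinary variation between repeated measurements. The new result also means that isopropoxy now stands with benzamido at the limit, leaving fluoro as the only one of the three groups at this aromatic carbon with an actual number, while the step between the two limit compounds cannot be read: the limit of > 100 ug/mL in this assay, at which 2 of the 3 values shown sit.

From the compounds shown here alone, how far compound 1 and compound 3 lie beyond that limit stays open, and so does whether they differ from each other at all. Going by these compounds, it is also open how an amine, a chloro group or a short ethoxy chain at this aromatic carbon would read, and whether any such group would give a value clearly lower than that of compound 2.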